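Replacing (6-bromopyridin-2-yl)methyl with propargyl

This account rests on a few compounds, and the source may have more. Where it says the series, first, only, none or still open, it means among the compounds named here.

In a functional assay on NFS-60 cells (Mus musculus) for inhibition, with a stated time of 72 h (a lower number here means a stronger inhibitor of growth, a higher number a weaker inhibitor of growth), compound 1 (`Nc1ncnc2c(C(=O)Nc3cccc4c3c(Br)nn4Cc3ccncc3)csc12`) reads 135 nM, compound 2 (`Nc1ncnc2c(C(=O)Nc3cccc4c3c(Br)nn4Cc3cccc(F)n3)csc12`) reads 233 nM and compound 3 (`Nc1ncnc2c(C(=O)Nc3cccc4c3c(Br)nn4Cc3cccc(Br)n3)csc12`) reads 243 nM on the same scale. Compound 3 sits within the scatter of both others, with a 1.0-fold higher number from compound 2 to compound 3 (0.02 log units; within the scatter) and a 1.8-fold higher number from compound 1 to compound 3 (0.26 log units; within the scatter) as its steps. Compound 4 (`C#CCn1nc(Br)c2c(NC(=O)c3csc4c(N)ncnc34)cccc21`) differs from compound 3 by ethynyl in place of 6-bromopyridin-2-yl on a saturated chain carbon bound to an aromatic nitrogen. Among the measured compounds shown here, three measured steps bear on this place. The step of a 1.7-fold higher number from compound 1 to compound 2 (0.24 log units; within the scatter) and the step of a 1.8-fold higher number from compound 1 to compound 3 (0.26 log units; within the scatter) swap one pyridinyl group for another, and the step of a 1.0-fold higher number from compound 2 to compound 3 (0.02 log units; within the scatter) swaps only the halogen. All stay within the scatter, yet none removes the aromatic ring, so they offer only loose guidance here. No step beyond the scatter is expected in this assay, and no direction is claimed. The estimate amounts to a 1.2-fold higher number from compound 3 to compound 4 (0.06 log units; within the scatter) (an expected value, not a measurement). Compound 4 is estimated at 280 nM (expected range 90 nM to 850 nM).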

Compound 4, concentration for 50% growth inhibition: > 10000 nM
Compound 4: a limit, no number (the forecaster's own chance of this, stated with the estimate: 3%); middle value at least 35-fold (1.55 log units) from the limit.
By their numbers in this assay, from the lowest: compounds 1, 2 and 3 (each within the scatter of the next). At a limit, above all of these: compound 4.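

In this assay compound 4 gives a limit, not a number: the limit of > 10000 nM in this assay, at which 1 of the 4 values shown sits.

The exchanges among the pyridinyl groups and the halogen swap all stayed within the scatter, but leaving the aromatic ring out of this substituent does not: an at least 41-fold higher number from compound 3 to compound 4 (1.61 log units; beyond the scatter), an at least 42-fold higher number from compound 2 to compound 4 (1.63 log units; beyond the scatter) and an at least 74-fold higher number from compound 1 to compound 4 (1.86 log units; beyond the scatter). In this series, the place on a saturated chain carbon bound to an aromatic nitrogen therefore accepts the three pyridinyl groups shown, while the change from (6-bromopyridin-2-yl)methyl to propargyl is a large loss that those earlier steps gave no sign of.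

The compounds shown do not separate the loss of the aromatic ring from the entry of the ethynyl group. From the compounds shown here alone, a benzyl group or a saturated propyl chain at this place would bear on that, and the true size of these steps stays open.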